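This account rests on a few compounds, and the source may have more. Where it says the series, first, only, none or still open, it means among the compounds named here.

Compound 1 `C=C1c2c(C)nc(OC)c(C#N)c2N=CN1CCC` gives > 50000 nM in a functional assay on KB cells (Homo sapiens) for cytotoxicity, read by MTT assay, with a stated time of 3 days (on this read-out higher numbers stand for weaker inhibition and lower numbers for stronger inhibition), which is a limit of the assay rather than a number.
Compound 2 `C=C1c2c(C)nc(OC)c(C#N)c2N=CN1Cc1ccco1` gives > 50000 nM in this assay, again a limit.

Both measured compounds sit at the same limit, as the limit of > 50000 nM in this assay, at which 2 of the 2 values shown sit, records, so compound 2 stands nowhere on a scale of numbers: it is simply not placed within the measurable range. Among the measured compounds shown here, the single measured step, a step that the two limits leave unreadable from compound 1 to compound 2, has no readable size, since both of its ends are limits. Compound 3 `C=C1c2c(C)nc(OC)c(C#N)c2N=CN1Cc1ccccc1` differs from compound 2 by phenyl in place of furan-2-yl on a saturated chain carbon bound to an amine nitrogen in a ring. For the measured compounds named here, no measured step bears on this change in a readable way, and the one step in hand gives neither a direction nor a size. Since neither measured compound shows inhibition within the range of this assay, compound 3 is expected to stay at the limit as well. The expected step is therefore a step that the limit leaves unreadable from compound 2 to compound 3. Compound 3 is estimated at 80000 nM, with a range from 20000 nM to 300000 nM, most likely reported only as a limit.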

Compound 3, half-maximal inhibitory concentration: > 50000 nM
Compound 3: a limit, no number (the forecaster's own chance of this, stated with the estimate: 85%); the middle value does not contradict the limit.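

Compounds 1, 2 and 3 all stand at a limit rather than a number, so no step among them can be read: the limit of > 50000 nM in this assay, at which 3 of the 3 values shown sit.

The compounds shown leave open how ethyl, furan-2-yl and phenyl rank against one another, and whether any change to the shared core gives a measurable value.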